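A few compounds are considered here, and "the series" means these few. Any claim that something is new, unique, unknown or untested is made for them only; others in the source may bear on it.

Measured so far in a functional assay on A549 cells (Homo sapiens) for cytotoxicity; on this read-out lower numbers stand for stronger inhibition and higher numbers for weaker inhibition:
- compound 1 `C=C/C=C\[C@H](C)[C@H](OC(N)=O)[C@@H](C)[C@H](O)[C@@H](C)C/C(C)=C\[C@H](C)[C@@H](O)[C@@H](C)/C=C\CCc1cccc(F)c1`: 650 nM
- compound 2 `C=C/C=C\[C@H](C)[C@H](OC(N)=O)[C@@H](C)[C@H](O)[C@@H](C)C/C(C)=C\[C@H](C)[C@@H](O)[C@@H](C)/C=C\CCc1cccc(O)c1C`: 910 nM

Among the measured compounds shown here, compound 1 has only one measured neighbour, and the two values lie within the scatter of each other: a 1.4-fold higher number from compound 1 to compound 2 (0.15 log units; within the scatter). That step exchanges the 3-fluorophenyl group of compound 1 for 3-hydroxy-2-methylphenyl, so the aromatic end of the chain has been altered once, with no change in this assay beyond the scatter.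

Compound 3 `C=C/C=C\[C@H](C)[C@H](OC(N)=O)[C@@H](C)[C@H](O)[C@@H](C)C/C(C)=C\[C@H](C)[C@@H](O)[C@@H](C)/C=C\CCc1cc(F)cc(F)c1` is not yet measured. It carries fluoro in place of hydrogen on an aromatic carbon of the same group, meta to a fluoro group and meta to a large group: fluoro in place of hydrogen on an aromatic carbon. The 3-fluorophenyl group thus becomes 3,5-difluorophenyl.

For the measured compounds named here, no measured pair isolates this exact change, so a 1.4-fold higher number from compound 1 to compound 2 (0.15 log units; within the scatter) is the only guide, and a single step supports no firm pattern. On that basis, no shift beyond the scatter is expected in this assay. The expected step is no change at the digits printed from compound 1 to compound 3 (within the scatter). For compound 3 the estimated value is 650 nM, with an expected range of 300 nM to 1400 nM.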

Compound 3, half-maximal inhibitory concentration: 1000 nM
Compound 3: middle estimate off by 1.5-fold (0.19 log units), on the low side; measured number inside the range.
By their numbers in this assay, from the lowest: compounds 1, 2 and 3 (each within the scatter of the next).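

In this assay, fluoro in place of hydrogen on an aromatic carbon, meta to a fluoro group and meta to a large group, gives a 1.5-fold higher number from compound 1 to compound 3 (0.19 log units; within the scatter), so this single-atom change to the 3-fluorophenyl group leaves the read-out within the scatter. The comparison with the other aromatic end, a 1.1-fold higher number from compound 2 to compound 3 (0.04 log units; within the scatter), is also within the scatter, and the 3-fluorophenyl, 3-hydroxy-2-methylphenyl and 3,5-difluorophenyl ends of compounds 1, 2 and 3 cannot be told apart in this assay. No data are available that would explain this flat read-out.

As far as these compounds go, it remains open whether a more drastic change at this end, such as an amine or a carboxylic acid on the aromatic ring, or a longer chain in place of the 2-(3-fluorophenyl)ethyl group, would move the number beyond the scatter. The three compounds also share the same core and differ only at the aromatic end, so they say nothing about how changes elsewhere in the molecule would read in this assay.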